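Hydrogen replaces (prop-1-en-1-yl)carbonyl in compound 4

The compounds below may be only part of what the source reports. "The series", "measured", "known", "first", "only" and "open" are said of these compounds alone.

Compound 3 (`C/C=C/C(=O)N(Cc1ccc(OC)c(C)c1)c1cc(OC)c(OC)c(OC)c1`) gives 14500 nM in a functional assay on MGC-803 cells (Homo sapiens) for inhibition, read by MTT assay, with a stated time of 48 h (on this read-out lower numbers stand for stronger inhibition and higher numbers for weaker inhibition), and so sits within the scatter of compound 1 (`COc1ccc(CNc2cc(OC)c(OC)c(OC)c2)cc1[N+](=O)[O-]`) at 19400 nM but lower than compound 2 (`COc1ccc(CNc2cc(OC)c(OC)c(OC)c2)cc1F`) at 39700 nM on this scale. Compound 4 (`COc1ccc(CNc2cc(OC)c(OC)c(OC)c2)cc1C`) brings one change (hydrogen in place of (prop-1-en-1-yl)carbonyl on a nitrogen on an aromatic ring): hydrogen in place of (prop-1-en-1-yl)carbonyl on a nitrogen on an aromatic ring. For the measured compounds named here, no measured step covers this change. The only one (a 2.0-fold higher number from compound 1 to compound 2 (0.31 log units; beyond the scatter)) was modest and swaps fluoro for nitro on an aromatic carbon instead. Hydrogen already sits on that nitrogen in compound 1 at 19400 nM and in compound 2 at 39700 nM as well. The estimated step (a 1.9-fold higher number from compound 3 to compound 4 (0.27 log units; within the scatter)) is therefore a small rise in this assay toward weaker inhibition, no larger than the scatter. Compound 4 is estimated at 27000 nM with an expected range from 12000 nM to 60000 nM on this read-out.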

Compound 4, half-maximal inhibitory concentration: 56800 nM
The estimate for compound 4 lay 2.1-fold (0.32 log units) below the measured number, and the stated range covers the measured number.
By their numbers in this assay, from the lowest: compounds 3 and 1 (each within the scatter of the next); then compounds 2 and 4 (each within the scatter of the next).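

In this assay, for the compounds shown here, hydrogen in place of (prop-1-en-1-yl)carbonyl on the nitrogen gives a 3.9-fold higher number from compound 3 to compound 4 (0.59 log units; beyond the scatter), the first measured change at this nitrogen, and it shows that the carbonyl-bearing compound 3 has the stronger inhibition. On the aromatic carbon, methyl in place of fluoro gives a 1.4-fold higher number from compound 2 to compound 4 (0.16 log units; within the scatter), while methyl in place of nitro gives a 2.9-fold higher number from compound 1 to compound 4 (0.47 log units; beyond the scatter), so methyl reads like fluoro and apart from nitro. Nothing available here explains these steps. Still open, from the compounds shown here alone, is whether a different group on that nitrogen, such as acetyl, would keep the stronger inhibition, and how an amine on the aromatic carbon would read.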